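Sulfur-linked dichlorophenyl analogue of a diamino core

This account rests on a few compounds, and the source may have more. Where it says the series, first, only, none or still open, it means among the compounds named here.

Compound 1, `Nc1cc(N)c2nc(-c3ccccc3)c(Oc3ccc(Cl)c(Cl)c3)nc2c1`: 33900 nM in a functional assay on Hs-578T cells (Homo sapiens) for inhibition, read by sulforhodamine B assay, with a stated time of 48 h; a lower number here means a stronger inhibitor of growth, a higher number a weaker inhibitor of growth
Compound 2, `Nc1cc(N)c2nc(-c3ccccc3)c(NCc3ccc(F)cc3)nc2c1`: in this assay compound 2 gives only the limit < 100000 nM
Compound 3, `COc1ccc(Sc2nc3cc(N)cc(N)c3nc2-c2ccccc2)cc1`: in this assay compound 3 gives only the limit < 100000 nM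

Compound 3 thus stands at a limit of this assay, not at a number, and the same holds for compound 2 (the limit of < 100000 nM in this assay, at which 2 of the 3 values shown sit). Against that, compound 1 is the only one of the three with a measured number. The steps from compound 1 to compound 2 a step that the limit leaves unreadable from compound 1 to compound 2, from compound 1 to compound 3 a step that the limit leaves unreadable from compound 1 to compound 3 and from compound 2 to compound 3 a step that the two limits leave unreadable from compound 2 to compound 3 are all unreadable. Their sizes cannot be read from the values at hand.

Compound 4, `Nc1cc(N)c2nc(-c3ccccc3)c(Sc3ccc(Cl)c(Cl)c3)nc2c1`, is not yet measured. Compared with compound 3 the change is 3,4-dichlorophenyl in place of 4-methoxyphenyl on a sulfur. Within the data shown here, no measured step with a readable size bears on this change. Compound 1 carries the same 3,4-dichlorophenyl ring on an oxygen and gives 33900 nM, which is the only anchor. On that basis compound 4 is expected to land near 30000 nM, within 8000 nM to 100000 nM. The expected step is a step that the limit leaves unreadable from compound 3 to compound 4, though with a limit at the start it cannot be read as a true change.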

Compound 4, concentration for total growth inhibition: < 100000 nM
Compound 4 gave a limit, no number; the forecaster's own chance of this, stated with the estimate: 40%; the middle value does not contradict the limit.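

In this assay compound 4 gives < 100000 nM, a limit and not a number. No step from compound 1, compound 2 or compound 3 to compound 4 can be read, because most values are limits: the limit of < 100000 nM in this assay, at which 3 of the 4 values shown sit.

From the compounds shown here alone, whether (3,4-dichlorophenyl)sulfanyl changes growth inhibition compared with 3,4-dichlorophenoxy or (4-methoxyphenyl)sulfanyl stays open.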